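Swapping one amide group: what to expect of compound 4

The source may hold more compounds than are shown below. What is called first, only, known or untested is meant among the compounds shown, and "the series" means these compounds.

Measured so far in an ADME assay on Caco-2 cells (Homo sapiens) for permeability, in the apical to basolateral direction; a lower number here means that the compound crosses the layer more slowly, a higher number that the compound crosses the layer faster:
Compound 1 `Cn1cncc1CN1CC(N(CC2CCN(C(=O)c3ccccc3)CC2)S(=O)(=O)c2ccccn2)Cc2cc(C#N)ccc21` gives 0.5 10^-6 cm/s
Compound 2 `Cn1cncc1CN1CC(N(CC2CCN(C(=O)CC(F)(F)F)CC2)S(=O)(=O)c2ccccn2)Cc2cc(C#N)ccc21` gives 0.5 10^-6 cm/s
Compound 3 `Cn1cncc1CN1CC(N(Cc2cccc(-n3cccc3)c2)S(=O)(=O)c2ccccn2)Cc2cc(C#N)ccc21` gives 2.3 10^-6 cm/s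

Compound 2 sits at 0.5 10^-6 cm/s on this scale, level with compound 1 and, together with it, the lowest so far. Compound 3 reads higher, at 2.3 10^-6 cm/s on the same scale.

The next compound, compound 4 `Cn1cncc1CN1CC(N(CC2CCN(C(=O)N3CCCC3)CC2)S(=O)(=O)c2ccccn2)Cc2cc(C#N)ccc21`, differs from compound 2 in one group (pyrrolidin-1-yl in place of 2,2,2-trifluoroethyl on a carbonyl carbon): pyrrolidin-1-yl in place of 2,2,2-trifluoroethyl on a carbonyl carbon. Among the measured compounds shown here, only one measured step touches that carbonyl carbon, where 2,2,2-trifluoroethyl took the place of phenyl (no change at the digits printed from compound 1 to compound 2 (within the scatter)). Compound 3 has no such carbonyl carbon, so its value offers no direct guide. For the measured compounds named here, one step is thin evidence, and no compound with pyrrolidin-1-yl has been measured yet.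

The step expected in this assay therefore stays within the scatter, in either direction (a 1.2-fold higher number from compound 2 to compound 4 (0.08 log units; within the scatter) is the estimate). The estimate for compound 4 is 0.6 10^-6 cm/s within an expected range of 0.3 10^-6 cm/s to 1.5 10^-6 cm/s (still to be measured).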

Compound 4, apparent permeability: 0.6 10^-6 cm/s
The estimate for compound 4 equals the measured number at the digits printed, within the range that was stated.
By their numbers in this assay, from the lowest: compounds 1, 2 and 4 (each within the scatter of the next); then compound 3.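

With pyrrolidin-1-yl on the carbonyl carbon, this assay shows a 1.2-fold higher number from compound 2 to compound 4 (0.08 log units; within the scatter) and a 1.2-fold higher number from compound 1 to compound 4 (0.08 log units; within the scatter) as the two new steps, so a third group now joins phenyl and 2,2,2-trifluoroethyl at this position. The three groups differ in their atoms, and 2,2,2-trifluoroethyl has no ring while pyrrolidin-1-yl has one, yet all three compounds lie within the scatter of one another, so no group tried at this position stands apart. Nothing shown gives a measured reason for this.

From the compounds shown here alone, whether a group carrying an amine or a carboxylic acid, or a longer chain, on this carbonyl carbon would also stay within the scatter remains open. Also open, going by these compounds, is whether the same groups would read alike on a different core, since all three steps start from the same shared core.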